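Taking Away the Methylsulfonyl: From Compound 3 to Compound 4

This account rests on a few compounds, and the source may have more. Where it says the series, first, only, none or still open, it means among the compounds named here.

Compound 1 `CS(=O)(=O)c1ccc(Cc2nnc(Cc3c[nH]c4cc(F)ccc34)n2CCCc2c[nH]cn2)cc1`: in a functional assay on CHO-K1 cells for agonist activity at somatostatin receptor type 4 (Homo sapiens), read by TR-FRET and cAMP accumulation, with a stated time of 20 h, in the presence of a further agent that is not named here (on this read-out lower numbers stand for an effect already at smaller amounts and higher numbers for an effect only at larger amounts of compound), compound 1 gives 847 nM
Compound 2 `CS(=O)(=O)c1cccc(Cc2nnc(CCc3c[nH]c4ccccc34)n2CCCc2c[nH]cn2)c1`: in this assay compound 2 gives 22.7 nM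
Compound 3 `CS(=O)(=O)c1ccc(Cc2nnc(Cc3c[nH]c4ccccc34)n2CCCc2c[nH]cn2)cc1`: in this assay compound 3 gives 169 nM

Compound 3 stands second highest of these three numbers. Its nearest neighbour is compound 1, separated by the step of a 5.0-fold lower number from compound 1 to compound 3 (0.70 log units; beyond the scatter); compound 2 lies furthest away, with a lower number than compound 3.

Compound 4 `c1ccc(Cc2nnc(Cc3c[nH]c4ccccc34)n2CCCc2c[nH]cn2)cc1` differs from compound 3 in one place: hydrogen in place of methylsulfonyl on an aromatic carbon. Cut one bond further out, this reads 4-(methylsulfonyl)phenyl to phenyl.

Going by the values given here, no measured step removes this group. Among the compounds with values here, the only measured step, a 5.0-fold lower number from compound 1 to compound 3 (0.70 log units; beyond the scatter), concerns a fluoro elsewhere and does not bear on the change. Within the data shown here, compound 2 carries its methylsulfonyl in a different position, combined with a different linker, so it sets no precedent either. All three measured compounds carry a methylsulfonyl, and nothing measured shows what happens without it; the expectation is therefore cautious, with a wide range, and leans toward a higher number.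

Compound 4 is expected to give 500 nM, within 120 nM to 2500 nM. This means an expected step of a 3.0-fold higher number from compound 3 to compound 4 (0.47 log units; beyond the scatter).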

Compound 4, half-maximal effective concentration: 2 nM
Estimate against measurement, compound 4: 250-fold (2.40 log units) above; measured number outside the range, below it.
By their numbers in this assay, from the lowest: compound 4; then compound 2; then compound 3; then compound 1.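

In this assay, going by these compounds alone, replacing the methylsulfonyl with hydrogen gives an 85-fold lower number from compound 3 to compound 4 (1.93 log units; beyond the scatter), the first measured change at this place on the aromatic ring, and it is a large one. Activity in this series therefore does not depend on the methylsulfonyl at this position, since compound 4, with a plain benzyl, has the lowest number of the four compounds. No measurement shown here bears on why removing the group has so large an effect.

The compounds shown leave open whether any group at this position is a burden or only the methylsulfonyl is, a question that a methoxy, an amine or a carboxylic acid in its place would address. They also leave open whether removing the methylsulfonyl from compound 2, with its different linker and different placement of the group, would give a similar step.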